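The compounds below may be only part of what the source reports. "The series", "measured", "known", "first", "only" and "open" are said of these compounds alone.

Measured in a functional assay on MCF7 cells (Homo sapiens) for cytotoxicity, read by MTT assay; on this read-out lower numbers stand for stronger inhibition and higher numbers for weaker inhibition:

Compound 1 `CC(=O)O[C@@H]1OC(=O)[C@](C)(C(C)=O)[C@@H]1C`: 6000 nM.
Compound 2 `CC(=O)O[C@@H]1OC(=O)[C@](C)(C(=O)CBr)[C@@H]1C`: 4000 nM.
Compound 3 `CC(=O)O[C@@H]1OC(=O)[C@@](C)(C(C)=O)[C@@H]1C`: > 10000 nM, a limit of the assay.

Compound 3 stands only at a limit in this assay; no number is known for it. Its stereoisomer compound 1 differs only in configuration as drawn, and the step of an at least 1.6-fold higher number from compound 1 to compound 3 (0.22 log units; that floor lies within the scatter). Compound 4 `CC(=O)O[C@@H]1OC(=O)[C@@](Cc2ccccc2)(C(C)=O)[C@@H]1C` carries phenyl in place of hydrogen on a saturated chain carbon bound to a saturated ring carbon. For the measured compounds named here, no measured step touches this position: the two known steps, a 1.5-fold lower number from compound 1 to compound 2 (0.18 log units; within the scatter) and an at least 1.6-fold higher number from compound 1 to compound 3 (0.22 log units; that floor lies within the scatter), concern a bromo substituent and a stereocentre, and both sit within the scatter. In this assay the step of a number no higher from compound 3 to compound 4 (the limit leaves the size open) is therefore expected to stay within the scatter of the limit. Compound 4 is estimated at 10000 nM, between 4000 nM and 30000 nM.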

Compound 4, half-maximal inhibitory concentration: 51000 nM
For compound 4 the middle estimate is 5.1-fold (0.71 log units) below the measured one; measured number above the stated range.
By their numbers in this assay, from the lowest: compounds 2 and 1 (each within the scatter of the next); then compound 4.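

Compound 3 stands only at a limit, so no new step can be read from compound 3 to compound 4. From the compounds shown here alone, what replacing methyl with benzyl does to the number on this shared core stays open.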